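Aryl group on the carbonyl carbon: three measured, one pending

The source may report more compounds than this note shows. Statements on the series, on what has been measured and on what is new or still open speak of the compounds shown alone.

Measured compounds in a functional assay on A549 cells (Homo sapiens) for antiproliferative activity, read by MTT assay, with a stated time of 48 h; on this read-out higher numbers stand for weaker inhibition and lower numbers for stronger inhibition:
compound 1 `CCCCOc1ccc(C(=O)/C=C/c2c(/C=C/c3ccc(OC)cc3)cc(OC)cc2OC)cc1` gives 8.7 ug/mL
compound 2 `COc1ccc(/C=C/c2cc(OC)cc(OC)c2/C=C/C(=O)c2ccccc2C)cc1` gives 5.9 ug/mL
compound 3 `CCCCCCCCCCCCOc1ccc(C(=O)/C=C/c2c(/C=C/c3ccc(OC)cc3)cc(OC)cc2OC)cc1` gives 7.9 ug/mL

Compound 2 has the lowest of the three numbers in this assay, but its gaps to compound 3 and to compound 1 are within the scatter, so no order among the three can be claimed.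

Compound 4 `CCN(CC)c1ccc(C(=O)/C=C/c2c(/C=C/c3ccc(OC)cc3)cc(OC)cc2OC)cc1` differs from compound 2 at the carbonyl carbon: 4-(diethylamino)phenyl in place of 2-methylphenyl on a carbonyl carbon.

Going by the values given here, two measured steps bear on the aryl group at this position. The change a 1.5-fold lower number from compound 1 to compound 2 (0.17 log units; within the scatter) swapped the aryl group on the carbonyl carbon and moved the number only within the scatter. The change a 1.1-fold lower number from compound 1 to compound 3 (0.04 log units; within the scatter) lengthened the chain on the aryl oxygen and likewise stayed within the scatter. Among the compounds with values here, neither step shows that this position moves the read-out of this assay beyond the scatter, although no step introduces a nitrogen-bearing group there, so the present change is not directly covered.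

On this basis compound 4 is expected to land close to compound 2 in this assay, with a step of a 1.1-fold higher number from compound 2 to compound 4 (0.04 log units; within the scatter) that is estimated to stay within the scatter. The estimated value for compound 4 is 6.5 ug/mL, with a range from 2.5 ug/mL to 17 ug/mL.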

Compound 4, half-maximal inhibitory concentration: 5.4 ug/mL
Estimate against measurement, compound 4: 1.2-fold (0.08 log units) above, and the stated range covers the measured number.
By their numbers in this assay, from the lowest: compounds 4, 2, 3 and 1 (each within the scatter of the next).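

In this assay, a nitrogen-bearing group now stands on this aryl ring, and the step to it from the 2-methylphenyl compound, a 1.1-fold lower number from compound 2 to compound 4 (0.04 log units; within the scatter), shows that 4-(diethylamino)phenyl in place of 2-methylphenyl on a carbonyl carbon does not move the number beyond the scatter, even with 11 heavy atoms entering for 7 and a hydrogen-bond acceptor entering where the leaving group has none. The second step, a 1.6-fold lower number from compound 1 to compound 4 (0.21 log units; within the scatter), shows the same for diethylamino in place of butoxy on an aromatic carbon, so exchanging the oxygen-linked chain for this nitrogen-linked group also gives no readable change. No measurement at hand offers an explanation for this flat response.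

Going by these compounds, whether a carboxylic acid or a primary amine on this aryl ring would take the number beyond the scatter remains open. All four compounds share the same core, so the effect of replacing a group on the shared core in this assay is also left open, and it cannot be inferred from the steps at the carbonyl carbon.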